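Aryl urea series: chloro for trifluoromethyl on compound 2

The source may report more compounds than this note shows. Statements on the series, on what has been measured and on what is new or still open speak of the compounds shown alone.

In a functional assay on NCI-H226 cells (Homo sapiens) for inhibition, read by sulforhodamine B assay, with a stated time of 48 h, tested at 10 uM (on this read-out lower numbers stand for a stronger effect and higher numbers for a weaker effect at the one concentration tested), compound 2 `O=C(Nc1cccc(-n2cc(-c3ccncc3)c(-c3cc(O)cc(Cl)c3)n2)c1)Nc1ccc(Cl)c(C(F)(F)F)c1` gives 41.2%, the lowest of the two numbers available; compound 1 `COc1cc(Cl)cc(-c2nn(-c3cccc(NC(=O)c4ccc(Cl)c(Cl)c4)c3)cc2-c2ccncc2)c1` gives 66.3%, a difference beyond the scatter. Compound 3 `O=C(Nc1cccc(-n2cc(-c3ccncc3)c(-c3cc(O)cc(Cl)c3)n2)c1)Nc1ccc(Cl)c(Cl)c1` differs from compound 2 by chloro in place of trifluoromethyl on an aromatic carbon. Going by the values given here, no step between measured compounds covers this kind of change, so its size is uncertain; a small shift toward a weaker effect, not beyond the scatter, is expected. Compound 3 is estimated at 48%, in a range from 30% to 66%. The expected step of a number 6.8 percentage points higher from compound 2 to compound 3 (within the scatter) is thus within the usual scatter.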

Compound 3, a percentage reported as activity, at one concentration (the size of the read-out at that concentration, not a potency): 14.5%
For compound 3 the middle estimate is 33.5 percentage points above the measured one; the measured number lies below the stated range.
By their numbers in this assay, from the lowest: compound 3; then compound 2; then compound 1.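

In this assay, going by these compounds alone, chloro in place of trifluoromethyl gives a number 26.7 percentage points lower from compound 2 to compound 3 (beyond the scatter), the first one-place comparison. On this aromatic carbon, ortho to a chloro group, the substituent therefore matters: the 3,4-dichlorophenyl urea gives the stronger effect of this pair at the one concentration tested. No measurement at hand accounts for the step.

The compounds shown leave open how a fluoro, a methyl or a nitrile on this carbon would read. From the compounds shown here alone, whether the same exchange gives a similar step with a different linker or core also stays open.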